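The compounds below may be only part of what the source reports. "The series", "measured", "known", "first", "only" and "open" are said of these compounds alone.

Compound 1 `COc1cc(/C=C/C(=O)/C=C/c2cccc3ccccc23)ccc1OCc1cn(CCCOc2cc(=O)oc3ccccc23)nn1`: 71%
Compound 2 `COc1ccccc1/C=C/C(=O)/C=C/c1ccc(OCc2cn(CCCOc3cc(=O)oc4ccccc34)nn2)c(OC)c1`: 50%
Compound 3 `COc1cccc(/C=C/C(=O)/C=C/c2ccc(OCc3cn(CCCOc4cc(=O)oc5ccccc45)nn3)c(OC)c2)c1`: 58%

These values come from a functional assay on THP-1 cells (Homo sapiens) for inhibition, read by sulforhodamine B assay, with a stated time of 48 h, tested at 50 uM; on this read-out higher numbers stand for more inhibition of growth at the one concentration tested and lower numbers for less inhibition of growth. Compound 3, at 58%, cannot be separated from compound 2 and falls clearly short of compound 1. The two comparisons are a number 8 percentage points higher from compound 2 to compound 3 (within the scatter) and a number 13 percentage points lower from compound 1 to compound 3 (beyond the scatter).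

Compound 4 `COc1ccc(/C=C/C(=O)/C=C/c2ccc(OCc3cn(CCCOc4cc(=O)oc5ccccc45)nn3)c(OC)c2)cc1OC` turns the 3-methoxyphenyl group of compound 3 into 3,4-dimethoxyphenyl: methoxy in place of hydrogen on an aromatic carbon, ortho to a methoxy group and para to a large group (methoxy in place of hydrogen on an aromatic carbon).

Within the data shown here, no measured step adds a methoxy group, so the evidence is indirect. Swapping 2-methoxyphenyl for 3-methoxyphenyl gave a number 8 percentage points higher from compound 2 to compound 3 (within the scatter). The larger replacements of naphthalen-1-yl gave only modest steps, a number 21 percentage points lower from compound 1 to compound 2 (beyond the scatter) and a number 13 percentage points lower from compound 1 to compound 3 (beyond the scatter). A small addition is therefore expected to stay within the scatter, in no firm direction. The estimated step is a number 2 percentage points higher from compound 3 to compound 4 (within the scatter). For compound 4 the expected value is 60%, within an estimated range of 45% to 75%.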

Compound 4, percent growth inhibition at one concentration: 73%
Estimate against measurement, compound 4: 13 percentage points below, within the range that was stated.
By their numbers in this assay, from the lowest: compounds 2 and 3 (each within the scatter of the next); then compounds 1 and 4 (each within the scatter of the next).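

In this assay, a methoxy group in place of hydrogen on the aromatic carbon ortho to a methoxy group and para to a large group gives a number 15 percentage points higher from compound 3 to compound 4 (beyond the scatter), which shows that this carbon is sensitive to a small added group. The resulting 3,4-dimethoxyphenyl group also compares well with 2-methoxyphenyl, giving a number 23 percentage points higher from compound 2 to compound 4 (beyond the scatter), and it stands level with naphthalen-1-yl, giving a number 2 percentage points higher from compound 1 to compound 4 (within the scatter), so a second methoxy group closes the gap that separated compound 3 from compound 1. Nothing available here explains why this single addition has such an effect.

As far as these compounds go, whether a hydroxyl group, an amino group or a chlorine atom on the same carbon would act as methoxy does remains open. A read-out at one concentration also leaves open how these compounds compare across a range of doses.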